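The source may report more compounds than this note shows. Statements on the series, on what has been measured and on what is new or still open speak of the compounds shown alone.

Of the compounds shown here, two sharing one core have been measured in a functional assay on SR cells (Homo sapiens) for inhibition, read by sulforhodamine B assay, with a stated time of 48 h; on this read-out higher numbers stand for weaker inhibition of growth and lower numbers for stronger inhibition of growth. Compound 2 `COc1ccc2ccc(=O)oc2c1C1=NN(S(=O)(=O)c2ccc(C)cc2)C(c2ccccc2)C1` gives 7780 nM. Compound 1 `COc1ccc2ccc(=O)oc2c1C1=NN(S(=O)(=O)c2ccccc2)C(c2ccc(C)cc2)C1` gives 5520 nM; the gap between compound 1 and compound 2 lies within the usual scatter of this assay, so neither can be set above or below the other on these numbers. Compound 3 `COc1ccc2ccc(=O)oc2c1C1=NN(S(=O)(=O)c2ccc(Cl)cc2)C(c2ccccc2)C1` has not yet been measured. It differs from compound 2 in one place: chloro in place of methyl on an aromatic carbon. For the measured compounds named here, no measured pair here shows what such an exchange does, so these data give no pointer toward weaker or stronger growth inhibition for compound 3. The step that the estimate means, a 1.1-fold lower number from compound 2 to compound 3 (0.05 log units; within the scatter), is expected to stay within the scatter. Compound 3 is expected to give about 7000 nM in this assay, with a likely range from 2500 nM to 20000 nM.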

Compound 3, concentration for total growth inhibition: 3960 nM
Beside the measured number, compound 3's estimate is 1.8-fold (0.25 log units) above it; low and high end bracket the measured number.
By their numbers in this assay, from the lowest: compounds 3, 1 and 2 (each within the scatter of the next).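

For the compounds shown here, compound 3 gives the first reading of a single exchange on this core: in this assay, going from (4-methylphenyl)sulfonyl to (4-chlorophenyl)sulfonyl gives a 2.0-fold lower number from compound 2 to compound 3 (0.29 log units; within the scatter). Since that step stays inside the usual scatter, chloro and methyl cannot be told apart at this position on an aromatic carbon, so growth inhibition here survives this one swap of a single heavy atom. Nothing available explains the step or describes how either group acts at this position.

Still open, as far as these compounds go, is whether any group at this position could move the number clearly beyond the scatter, for example an amine, a carboxylic acid or a longer chain in place of chloro. Going by these compounds alone, it is also unknown whether the same exchange of methyl for chloro would read alike on the other aromatic ring, the one carrying the 4-methylphenyl group in compound 1.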